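The source may hold more compounds than are shown below. What is called first, only, known or untested is meant among the compounds shown, and "the series" means these compounds.

Measured so far:
Compound 1 `C[C@H](C(=O)NCc1ccc(C(F)(F)F)nc1C1CCC(C)(C)CC1)c1ccc(NS(C)(=O)=O)c(F)c1` gives 0.3 nM in an assay on CHO cells for antagonist activity at transient receptor potential cation channel subfamily V member 1 (Homo sapiens), read by FLIPR and calcium flux; on this read-out higher numbers stand for weaker inhibition and lower numbers for stronger inhibition.
Compound 2 `CC(C(=O)NCc1ccc(C(F)(F)F)nc1C1=CCC(C)(C)CC1)c1ccc(NS(C)(=O)=O)c(F)c1` gives 0.2 nM in this assay.

Of the two numbers, compound 2 has the lower one, yet its gap to compound 1 is within the scatter, so the two cannot be told apart on these data. The next compound to be measured is compound 3 `C[C@H](C(=O)NCc1ccc(C(F)(F)F)nc1C1=CCC(C)(C)CC1)c1ccc(NS(C)(=O)=O)c(F)c1`. Its difference from compound 2 is the two compounds have the same atoms and bonds; at least one stereo element is drawn with a configuration in one of them and without one in the other: 1 of 1 stereo elements differ; a stereocentre at a saturated chain carbon is drawn without a configuration in compound 2 and S in compound 3; in plain words, compound 2 carries the stereocentre at the saturated chain carbon drawn without a configuration, while compound 3 fixes that centre as S, and everything else is the same. Compound 1 also has this centre drawn as S and gives a strongly inhibiting number, so the S configuration is compatible with strong inhibition. The step from compound 2 to compound 3 is expected to be small, toward a lower number, and no larger than the scatter, at about a 1.3-fold lower number from compound 2 to compound 3 (0.12 log units; within the scatter). Compound 3 is therefore expected to give about 0.15 nM in this assay, within a range of 0.06 nM to 0.4 nM.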

Compound 3, inhibition constant: 0.1 nM
For compound 3 the middle estimate is 1.5-fold (0.18 log units) above the measured one; low and high end bracket the measured number.
By their numbers in this assay, from the lowest: compounds 3, 2 and 1 (each within the scatter of the next, the first and the last beyond it).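

Fixing the saturated chain carbon as S gives a 2.0-fold lower number from compound 2 to compound 3 (0.30 log units; within the scatter) in this assay and so leaves the two compounds indistinguishable on these numbers. This reading concerns one feature only (what separates the pair is this: the fact that one of compounds 2 and 3 is drawn with a defined configuration and the other without, at the place where they differ). Going by these compounds alone, with S drawn in both compounds, 4,4-dimethylcyclohex-1-en-1-yl in place of 4,4-dimethylcyclohexyl on an aromatic carbon gives a 3.0-fold lower number from compound 1 to compound 3 (0.48 log units; beyond the scatter) as a modest step, and it is the first comparison here that isolates this ring change, whereas compounds 1 and 2 differ in both the ring and the drawn configuration.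

From the compounds shown here alone, how the R configuration at the chain carbon would read remains open, so no preference for S can be stated. Also open, going by these compounds, is whether a phenyl or piperidine group at that aromatic carbon would keep numbers this low.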